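A Fluoro for Methoxy Swap in an Inactive Series

The source may report more compounds than this note shows. Statements on the series, on what has been measured and on what is new or still open speak of the compounds shown alone.

Of the compounds shown here, three have so far been measured in a functional assay on HL-60 cells (Homo sapiens) for cytotoxicity, read by MTT assay, with a stated time of 4 days; on this read-out higher numbers stand for weaker inhibition and lower numbers for stronger inhibition. Compound 1 `C=C1C[C@]23C[C@@]1(O)CC[C@H]2c1ccc(OS(=O)(=O)c2ccc(C)cc2)c(C)c1[C@@H]3Cn1cc(-c2ccc(Cl)cc2)nn1` carries a chloro on its outer aromatic ring; in this assay compound 1 gives only a limit, > 20000 nM. Compound 2 `C=C1C[C@]23C[C@@]1(O)CC[C@H]2c1ccc(OS(=O)(=O)c2ccc(C)cc2)c(C)c1[C@@H]3Cn1cc(-c2ccc(OC)cc2)nn1` differs by methoxy in place of chloro on an aromatic carbon, and in this assay compound 2 likewise reaches only a limit, > 20000 nM. Compound 3 `C=C1C[C@]23C[C@@]1(O)CC[C@H]2c1cc(Br)c(O)c(C)c1[C@@H]3Cn1cc(-c2ccc(OC)cc2)nn1` also returns only a limit in this assay, > 20000 nM. Among the compounds with values here, the one single-place step, a step that the two limits leave unreadable from compound 1 to compound 2, cannot be read in size or direction because both of its ends sit at the limit of > 20000 nM in this assay, at which 3 of the 3 values shown sit. On the numbers shown, compound 2 therefore stands at the limit, where every other value in the set also stands.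

Compound 4 `C=C1C[C@]23C[C@@]1(O)CC[C@H]2c1ccc(OS(=O)(=O)c2ccc(C)cc2)c(C)c1[C@@H]3Cn1cc(-c2ccc(F)cc2)nn1` is the compound not yet measured. It differs from compound 2 by fluoro in place of methoxy on an aromatic carbon. Within the data shown here, no measured step speaks directly to this change; the only step available, from chloro to methoxy, is unreadable. With three values at the limit and nothing pointing either way, the step expected in this assay, a step that the limit leaves unreadable from compound 2 to compound 4, is one that keeps compound 4 beyond what the assay resolves. Compound 4 is therefore expected to give about 30000 nM, with an estimated range from 8000 nM to 100000 nM, and most likely to be reported again as a limit rather than a number.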

Compound 4, half-maximal inhibitory concentration: > 20000 nM
Compound 4 was reported as a limit (the forecaster's own chance of this, stated with the estimate: 85%); the middle value does not contradict the limit.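

In this assay compound 4 again gives only a limit (> 20000 nM). The steps joining compound 4 to compound 1 and compound 2 therefore cannot be read in size or direction, since all values sit at the same limit: the limit of > 20000 nM in this assay, at which 4 of the 4 values shown sit.

Whether fluoro, chloro and methoxy differ at all in this assay stays open for the compounds shown.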